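Trading the aryl amide of compound 1 for a lactam

The source may hold more compounds than are shown below. What is called first, only, known or untested is meant among the compounds shown, and "the series" means these compounds.

Compound 1 `CNC(=O)c1ccc(-c2nc(COc3cc(OC)cc4oc(-c5cn6nc(OC)sc6n5)cc34)cs2)cc1` was tested in a functional assay on HEK293 cells for antagonist activity at proteinase-activated receptor 4 (Homo sapiens), read by FLIPR and calcium flux, with a stated time of 30 min (on this read-out higher numbers stand for weaker inhibition and lower numbers for stronger inhibition), where compound 1 gives 0.4 nM. Among the three measured compounds it has the second highest number: compound 2 `COc1cc(OCc2csc(-c3ccc(C(N)=O)cc3)n2)c2cc(-c3cn4nc(OC)sc4n3)oc2c1` gives 0.3 nM, and compound 3 `COc1cc(OCc2csc(-c3ccc(S(C)(=O)=O)cc3)n2)c2cc(-c3cn4nc(OC)sc4n3)oc2c1` gives 0.8 nM. The steps between them are small: a 1.3-fold lower number from compound 1 to compound 2 (0.12 log units; within the scatter), a 2.0-fold higher number from compound 1 to compound 3 (0.30 log units; within the scatter) and a 2.7-fold higher number from compound 2 to compound 3 (0.43 log units; beyond the scatter). All three keep the phenyl ring attached to the five-membered aromatic ring with 1 nitrogen and 1 sulfur and vary only the group carried on it, so the series shows that methylcarbamoyl, carbamoyl and methylsulfonyl are all accepted there with little movement in this assay.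

Compound 4 `COc1cc(OCc2csc(N3CCOCC3=O)n2)c2cc(-c3cn4nc(OC)sc4n3)oc2c1` departs further from compound 1: 3-oxomorpholin-4-yl in place of 4-(methylcarbamoyl)phenyl on an aromatic carbon. The 4-(methylcarbamoyl)phenyl, with its aromatic ring and hydrogen-bond donor, leaves, and the smaller 3-oxomorpholin-4-yl, with no donor, enters. For the measured compounds named here, no measured step removes the phenyl ring itself, so the three small steps bear on this change only loosely. The author therefore expects a step larger than any of them, toward a higher number: a 10-fold higher number from compound 1 to compound 4 (1.00 log units; beyond the scatter). On that basis compound 4 is estimated at 4 nM, within a range from 0.6 nM to 30 nM.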

Compound 4, half-maximal inhibitory concentration: 1.7 nM
For compound 4 the middle estimate is 2.4-fold (0.37 log units) above the measured one, within the range that was stated.
By their numbers in this assay, from the lowest: compounds 2, 1 and 3 (each within the scatter of the next, the first and the last beyond it); then compound 4.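

The six-membered aromatic ring of carbon only is not needed for activity at this position: on the aromatic carbon next to the ring nitrogen and next to the ring sulfur, a six-membered non-aromatic ring with 2 hetero atoms, 3-oxomorpholin-4-yl, keeps the compound active in this assay with only a modest loss. The cost of replacing the whole aryl group can now be read against each earlier compound as a 4.3-fold higher number from compound 1 to compound 4 (0.63 log units; beyond the scatter) and as a 2.1-fold higher number from compound 3 to compound 4 (0.33 log units; beyond the scatter) and as a 5.7-fold higher number from compound 2 to compound 4 (0.75 log units; beyond the scatter), which places compound 4 as the weakest of the four, since all three steps lie beyond the scatter. Nothing measured here accounts for the size of these steps.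

Because this one change removes the phenyl ring and its amide together and brings in the lactam, the compounds shown leave open how much of the loss belongs to each part. A plain morpholin-4-yl without the carbonyl, a piperazine carrying an amine, or a pyridine ring bearing the carbamoyl group would separate these parts, and a carboxylic acid on the phenyl ring would test the range of groups accepted there.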